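This account rests on a few compounds, and the source may have more. Where it says the series, first, only, none or still open, it means among the compounds named here.

Of the compounds shown here, three have been measured in a functional assay on the whole organism (strain albino) for inhibition, with Rattus norvegicus as the target, read by paw edema, with stated times of 30 min and 2 h, at a dose of 100 mg/kg by the oral route (on this read-out lower numbers stand for less inhibition and higher numbers for more inhibition at the one dose given (going by the name of the read-out)), and a fourth awaits measurement. Among the compounds with values here, compound 1, with the structure `CC(=O)c1ccc(OCC(=O)Nc2ccc(C(=O)/C=C/c3ccc(Cl)cc3)cc2)cc1`, is the first reference point; in this assay compound 1 gives 52%. Compound 2, with the structure `COc1ccc(/C=C/C(=O)c2ccc(NC(=O)COc3ccc(C(C)=O)cc3)cc2)cc1`, shares the core of compound 1 and differs from it in one place, namely (methoxy in place of chloro on an aromatic carbon). In this assay compound 2 gives 35%, so that the change made a number 17 percentage points lower from compound 1 to compound 2 (beyond the scatter).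

Compound 3, with the structure `O=C(COCc1c(-c2ccccc2)no[n+]1[O-])Nc1ccc(C(=O)/C=C/c2ccc(Cl)cc2)cc1`, carries a different core; how the two cores differ is not broken down here. In this assay compound 3 gives 48%, a number that sits within the usual scatter of the value of compound 1, while the value of compound 2 lies beyond the scatter below it.

Compound 4, with the structure `COc1ccc(/C=C/C(=O)c2ccc(NC(=O)COCc3c(-c4ccccc4)no[n+]3[O-])cc2)cc1`, is built on the core of compound 3 and differs from it only in methoxy in place of chloro on an aromatic carbon. The place of this change reads the same, word for word, as for the change from compound 1 to compound 2, so it is the same change made on a second core. Since the measured pair showed a modest fall, the change from compound 3 to compound 4 is expected to make a number 16 percentage points lower from compound 3 to compound 4 (beyond the scatter). Compound 4 is therefore estimated to give 32%, with a range from 18% to 46%, an expectation resting on a single measured step.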

Compound 4, a percentage reported as inhibition, in the whole organism at one dose (the size of the read-out at that dose, not a potency): 42%
For compound 4 the middle estimate is 10 percentage points below the measured one, within the range that was stated.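

The swap from 4-chlorophenyl to 4-methoxyphenyl on the second core gives a number 6 percentage points lower from compound 3 to compound 4 (within the scatter), so on this core the change cannot be told apart from the ordinary spread of repeated measurements in this assay. Set beside the first core, the two steps cannot be told apart either: the same change on two cores in this assay, a number 17 percentage points lower (beyond the scatter) from compound 1 to compound 2 and a number 6 percentage points lower (within the scatter) from compound 3 to compound 4, 11 percentage points apart, within the scatter of two such steps This means the data give no sign that the core alters what the change does, but they do not prove that the change does the same on both cores, since a real difference of a size smaller than the scatter would go unseen, and two pairs say nothing about any further core.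

The compounds shown carry only chloro or methoxy at this place on the ring, so it remains open how a hydroxy group, an amine, a carboxylic acid or a longer alkoxy chain there would read in this assay. Each number also describes a single oral dose, so the series gives the size of the read-out at that dose and leaves open how the compounds would compare in potency across a range of doses.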